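Chlorophenyl amide on the shared core of compound 1

This account rests on a few compounds, and the source may have more. Where it says the series, first, only, none or still open, it means among the compounds named here.

Compound 1 `CC(C)=CC(=O)Nc1c(C(O)(C(F)(F)F)C(F)(F)F)ccc2ccccc12`: 550 nM
Compound 2 `O=C(Nc1c(C(O)(C(F)(F)F)C(F)(F)F)ccc2ccccc12)C1CCC1`: 81.3 nM
Compound 3 `O=C(Nc1c(C(O)(C(F)(F)F)C(F)(F)F)ccc2ccccc12)c1cccc(Cl)c1`: 851 nM

All three were measured in a functional assay (Sus scrofa) with sulfonylurea receptors; K-ATP channels (Homo sapiens) as the target; a lower number here means that less compound is needed, a higher number that more compound is needed for the effect. Compound 1 has the second highest of the three numbers; its nearest neighbour is compound 3, with a 1.5-fold higher number from compound 1 to compound 3 (0.19 log units; within the scatter), and its furthest is compound 2, with a 6.8-fold lower number from compound 1 to compound 2 (0.83 log units; beyond the scatter). Compound 4 `O=C(Nc1c(C(O)(C(F)(F)F)C(F)(F)F)ccc2ccccc12)c1ccc(Cl)cc1` is not yet measured and differs from compound 1 in one place: 4-chlorophenyl in place of 2-methylprop-1-en-1-yl on a carbonyl carbon. The step to compound 3, which also carries a chlorophenyl group on the carbonyl carbon, stayed within the scatter, while a 10-fold higher number from compound 2 to compound 3 (1.02 log units; beyond the scatter) was large. Compound 4 is therefore expected to land close to compound 1 and compound 3, a 1.4-fold higher number from compound 1 to compound 4 (0.13 log units; within the scatter), estimated at 750 nM with a range from 300 nM to 2000 nM.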

Compound 4, half-maximal effective concentration: 389 nM
Compound 4: the middle estimate sits 1.9-fold (0.29 log units) above what was measured, within the range that was stated.
By their numbers in this assay, from the lowest: compound 2; then compounds 4, 1 and 3 (each within the scatter of the next, the first and the last beyond it).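

In this assay the place of the chlorine on the phenyl ring counts: swapping 3-chlorophenyl for 4-chlorophenyl alone gives a 2.2-fold lower number from compound 3 to compound 4 (0.34 log units; beyond the scatter) on the same carbonyl carbon. The 4-chlorophenyl group brings more heavy atoms than 2-methylprop-1-en-1-yl, yet the two cannot be told apart, with a 1.4-fold lower number from compound 1 to compound 4 (0.15 log units; within the scatter) in this pair. Cyclobutyl keeps the lowest number, with a 4.8-fold higher number from compound 2 to compound 4 (0.68 log units; beyond the scatter) separating it from the new amide.

Nothing measured here explains these differences. As far as these compounds go, how a plain phenyl, 2-chlorophenyl or cyclopentyl on this carbonyl carbon would compare also stays open.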